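The source may hold more compounds than are shown below. What is called first, only, known or untested is meant among the compounds shown, and "the series" means these compounds.

In a functional assay on L1210 cells (Mus musculus) for inhibition (a higher number here means a weaker inhibitor, a lower number a stronger inhibitor), compound 1, `C=Cc1cc(O)nc(O)n1`, gives 3000 nM, compound 2, `C=Cc1nc(O)nc(O)c1Cl`, gives 4500 nM and compound 3, `C=Cc1nc(O)nc(O)c1I`, gives 2000 nM. Compound 1 thus stands within the scatter of both of the others, and only the two halogenated compounds are separated by more than that.

The next compound, compound 4, `C/C=C\c1cc(O)nc(O)n1`, changes the group that the other three share: it carries prop-1-en-1-yl in place of vinyl on an aromatic carbon.

For the measured compounds named here, no measured step touches that group, so the available steps bear on the change only indirectly. Chloro in place of hydrogen gives a 1.5-fold higher number from compound 1 to compound 2 (0.18 log units; within the scatter), and iodo in place of hydrogen gives a 1.5-fold lower number from compound 1 to compound 3 (0.18 log units; within the scatter). Iodo in place of chloro gives a 2.3-fold lower number from compound 2 to compound 3 (0.35 log units; beyond the scatter), the largest step seen and still a modest one. Going by the values given here, these steps show only that changes elsewhere on the shared core have moved the number little.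

With compound 1 at 3000 nM as the reference, no step beyond the scatter is expected, although the missing data on this group call for a wide range. The expected step is a 1.3-fold higher number from compound 1 to compound 4 (0.12 log units; within the scatter). For compound 4 the estimated value is 4000 nM, with an expected range from 1200 nM to 20000 nM.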

Compound 4, half-maximal inhibitory concentration: 46000 nM
Compound 4: the middle estimate sits 12-fold (1.06 log units) below what was measured; the whole stated range lies below it.
By their numbers in this assay, from the lowest: compounds 3, 1 and 2 (each within the scatter of the next, the first and the last beyond it); then compound 4.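

For the compounds shown here, replacing vinyl with prop-1-en-1-yl on the aromatic carbon next to the ring nitrogen gives a 15-fold higher number from compound 1 to compound 4 (1.19 log units; beyond the scatter) in this assay, a large step beside the modest 2.3-fold lower number from compound 2 to compound 3 (0.35 log units; beyond the scatter), which was the largest among the earlier compounds. This position therefore tolerates far less change than the earlier halogen steps on the shared core would suggest, and it does so for a small change: prop-1-en-1-yl has 3 heavy atoms against 2 for vinyl, both groups are all carbon, and each has 1 double bond outside aromatic rings, no ring and no hydrogen-bond donors or acceptors. Nothing measured here accounts for the size of this step.

With a single change at this position, the compounds shown leave open whether the higher number follows from the added carbon or from the particular double-bond arrangement of prop-1-en-1-yl, a question that an ethyl group, a propyl chain or the other double-bond isomer would help to settle. They also leave open whether chloro or iodo on the shared core would shift the number in the same way when prop-1-en-1-yl replaces vinyl.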